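A few compounds are considered here, and "the series" means these few. Any claim that something is new, unique, unknown or untested is made for them only; others in the source may bear on it.

Measured in an ADME assay on NCM460 cells (Homo sapiens) for cytotoxicity, read by CCK-8 assay, with a stated time of 48 h; a higher number here means a weaker inhibitor, a lower number a stronger inhibitor:
Compound 1 `COc1ccc(/C=C\c2cc(OC)c(OC)c(OC)c2)cc1OCc1ccc(CN2CCCC[C@H]2C(=O)O)cc1`: > 50000 nM, a limit.
Compound 2 `COc1ccc(/C=C\c2cc(OC)c(OC)c(OC)c2)cc1OCc1ccc(CN2CCCCC2C(=O)O)cc1`: > 50000 nM, a limit.
Compound 3 `COc1ccc(/C=C\c2cc(OC)c(OC)c(OC)c2)cc1OCc1ccc(CO)cc1`: > 50000 nM, a limit.

Compound 3 has no number to start from, and the series as a whole stands at the limit of > 50000 nM in this assay, at which 3 of the 3 values shown sit. The change to compound 4 `COc1ccc(/C=C\c2cc(OC)c(OC)c(OC)c2)cc1OCc1ccc(CN2CC(C(=O)O)C2)cc1` is 3-carboxyazetidin-1-yl in place of hydroxy on a saturated chain carbon bound to an aromatic carbon.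

The nearest evidence is the exchange of 2-carboxypiperidin-1-yl and hydroxy at that same place, seen as a step that the two limits leave unreadable from compound 1 to compound 3 and as a step that the two limits leave unreadable from compound 2 to compound 3. The remaining measured step, a step that the two limits leave unreadable from compound 1 to compound 2, concerns only the fact that one of compounds 1 and 2 is drawn with a defined configuration and the other without, at the place where they differ and does not touch the present change. None of these steps gives a size or a direction. With compound 1 and compound 2 offering only unreadable steps, no shift beyond the scatter is expected in this assay, and compound 4 will most likely report a limit again. The expected step is a step that the limit leaves unreadable from compound 3 to compound 4. Compound 4 is estimated at 70000 nM, with an expected range from 30000 nM to 200000 nM.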

Compound 4, half-maximal inhibitory concentration: > 50000 nM
Compound 4 gave a limit, no number; the forecaster's own chance of this, stated with the estimate: 85%; the middle value is on the limit's open side.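

In this assay compound 4 gives > 50000 nM, a limit. The steps to compound 4 from compound 1, compound 2 and compound 3 cannot be read, so no new step comes from this result: the limit of > 50000 nM in this assay, at which 4 of the 4 values shown sit.

Left open is whether any group on the saturated chain carbon bound to an aromatic carbon shifts this read-out: none of the compounds shown gives a number.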